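The source may report more compounds than this note shows. Statements on the series, on what has been measured and on what is new or still open speak of the compounds shown alone.

Measured so far:
- compound 1, `COc1ccc(CNc2nc([Se]C)nc3ccccc23)cc1` — in a functional assay on MCF7 cells (Homo sapiens) for cytotoxicity, read by MTT assay, with a stated time of 72 h (on this read-out higher numbers stand for weaker inhibition of growth and lower numbers for stronger inhibition of growth), compound 1 gives 42200 nM
- compound 2, `CSc1nc(NCc2ccc([Se]C)cc2)c2ccccc2n1` — in this assay compound 2 gives 36400 nM

Both numbers are weak and sit close together. Compound 2 has the lowest of the two numbers, and its nearest neighbour, compound 1, is within the scatter of it, so no order between them can be read from these two values.

Compound 3, `COc1ccc(CNc2nc(SC)nc3ccccc23)cc1`, is not yet measured. It differs from compound 2 in one place: a group of 2 heavy atoms (1 carbon, 1 oxygen; no ring) in place of a group of 2 heavy atoms (1 carbon, 1 selenium; no ring), on an aromatic carbon. For the measured compounds named here, no step between measured compounds covers this change, so the expectation rests only on the weak and similar numbers of compound 1 and compound 2.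

Compound 3 is expected to stay in the same weak region, with a step from compound 2 of a 1.1-fold higher number from compound 2 to compound 3 (0.04 log units; within the scatter) that is not expected to exceed the scatter. For compound 3 the estimate in this assay is 40000 nM, with a range from 15000 nM to 100000 nM.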

Compound 3, concentration for 50% growth inhibition: 30900 nM
Compound 3: middle estimate off by 1.3-fold (0.11 log units), on the high side; the range from low to high includes it.
By their numbers in this assay, from the lowest: compounds 3, 2 and 1 (each within the scatter of the next).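

In this assay, methoxy in place of the group of one carbon and one selenium, on an aromatic carbon para to a large group, gives a 1.2-fold lower number from compound 2 to compound 3 (0.07 log units; within the scatter), so the two groups cannot be told apart at this position. The group of one carbon and one sulfur in place of the group of one carbon and one selenium, on an aromatic carbon of the shared core, gives a 1.4-fold lower number from compound 1 to compound 3 (0.14 log units; within the scatter), so exchanging selenium for sulfur at that place likewise shows no readable change. Nothing is available that would account for these two results.

Whether any group can move the number out of this weak region stays open, since all the changes shown swap groups of equal heavy-atom count. An amine or a carboxylic acid in place of methoxy, or a longer chain in place of the group holding sulfur, would test how far each place responds.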